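A few compounds are considered here, and "the series" means these few. Any claim that something is new, unique, unknown or untested is made for them only; others in the source may bear on it.

Measured so far: compound 1 `Cc1cccc(N(C)CC2CCC/C(=C\c3ccccc3)C2=O)c1`, 46.8%; compound 2 `Cc1ccc(N(C)CC2CCC/C(=C\c3ccc(S(C)(=O)=O)cc3)C2=O)cc1`, 31.9%.

In a functional assay on the whole organism (strain Wistar) for inhibition, with Rattus norvegicus as the target, read by paw edema, with stated times of 1 h and 3 h, at a dose of 200 mg/kg by the oral route (a lower number here means less inhibition, a higher number more inhibition at the dose given (going by the name of the read-out)), compound 2 stands lowest of the two numbers, and its nearest neighbour is compound 1, which in this assay gives 46.8%, a gap beyond the scatter. Compound 3 `Cc1cccc(N(C)CC2CCC/C(=C\c3ccc(S(C)(=O)=O)cc3)C2=O)c1` is not yet measured. It differs from compound 2 in one place: 3-methylphenyl in place of 4-methylphenyl on an amine nitrogen. Among the compounds with values here, no step between measured compounds that differ in one place is known, so the change itself is uncalibrated; a step of about a number 4.1 percentage points higher from compound 2 to compound 3 (within the scatter) is expected, within the scatter and not a real shift. Compound 3 is estimated at 36%, in a range from 22% to 50%.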

Compound 3, a percentage reported as inhibition, in the whole organism at one dose (the size of the read-out at that dose, not a potency): 36.2%
The estimate for compound 3 lay 0.2 percentage points below the measured number; the range from low to high includes it.
By their numbers in this assay, from the lowest: compounds 2 and 3 (each within the scatter of the next); then compound 1.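

In this assay, 3-methylphenyl in place of 4-methylphenyl on the amine nitrogen gives a number 4.3 percentage points higher from compound 2 to compound 3 (within the scatter) and so shows no real shift at this position. Methylsulfonyl in place of hydrogen on an aromatic carbon gives a number 10.6 percentage points lower from compound 1 to compound 3 (beyond the scatter) and is the one change here that exceeds the scatter, if only modestly. Nothing measured on these compounds offers an explanation for either step.

On these data alone, what 2-methylphenyl on the amine nitrogen would give remains open. So does whether a carboxylic acid or a fluorine atom in place of methylsulfonyl would give a similar step.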